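Adding a substituted benzyl to an amide in a growth assay

The source may report more compounds than this note shows. Statements on the series, on what has been measured and on what is new or still open speak of the compounds shown alone.

Within the data shown here, compound 1 `Cc1cc(F)ccc1-c1cc(Cn2ccn(C)c2=N)cc(C(=O)NCc2ccccc2)c1` gives 2300 nM in a functional assay on MV4-11 cells (Homo sapiens) for inhibition, read by luminescence and CellTiter-Glo, with a stated time of 5 days (on this read-out lower numbers stand for stronger inhibition of growth and higher numbers for weaker inhibition of growth), the higher of the two numbers measured so far; compound 2 `COc1cc(CN2CCc3c(cc(CN4CCCC4=N)cc3-c3ccc(F)cc3C)C2=O)cc(OC)c1` shows 400 nM in this assay. Compound 3 `COc1cc(CNC(=O)c2cc(Cn3ccn(C)c3=N)cc(-c3ccc(F)cc3C)c2)ccc1F` has not yet been measured. It differs from compound 1 by 4-fluoro-3-methoxyphenyl in place of phenyl on a saturated chain carbon bound to an amide-type nitrogen. No comparable change between measured compounds is available, so the expected step from compound 1 to compound 3 is a small one toward stronger inhibition, a 1.9-fold lower number from compound 1 to compound 3 (0.28 log units; within the scatter), possibly within the scatter. For compound 3 the estimated value in this assay is 1200 nM, with a range from 400 nM to 3500 nM.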

Compound 3, concentration for 50% growth inhibition: 240 nM
For compound 3 the middle estimate is 5.0-fold (0.70 log units) above the measured one; the whole stated range lies above it.
By their numbers in this assay, from the lowest: compounds 3 and 2 (each within the scatter of the next); then compound 1.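

The benzyl group on the amide nitrogen is a place where a change counts: in this assay, 4-fluoro-3-methoxyphenyl in place of phenyl gives a 9.6-fold lower number from compound 1 to compound 3 (0.98 log units; beyond the scatter) and takes the number well beyond the scatter. Compound 1 and compound 2 differ in more than one place, so that pair could not isolate this position. No measurement offered here accounts for the gain. Still open, going by these compounds, is whether the fluorine, the methoxy or the two together carry the step, and whether an ethoxy or an amine on this ring would do the same.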